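Swapping the aryl group on the pyrazole nitrogen: chlorines for methyl

The source may report more compounds than this note shows. Statements on the series, on what has been measured and on what is new or still open speak of the compounds shown alone.

Three compounds share one core and differ only in the ring attached to an aromatic nitrogen. In a functional assay with Homo sapiens as the target (a lower number here means a stronger inhibitor, a higher number a weaker inhibitor), compound 1 `Cc1c(C(=O)Nc2ccc(C(F)(F)F)cc2)cnn1-c1ccc(F)c(Cl)c1` gives 1300 nM, compound 2 `Cc1c(C(=O)Nc2ccc(C(F)(F)F)cc2)cnn1-c1ccc([N+](=O)[O-])cc1` gives 5700 nM and compound 3 `Cc1cccc(-n2ncc(C(=O)Nc3ccc(C(F)(F)F)cc3)c2C)c1` gives 2500 nM. Compound 3 thus sits second highest of the three, within the scatter of compound 1 and beyond it from compound 2, with a 2.3-fold lower number from compound 2 to compound 3 (0.36 log units; beyond the scatter).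

Compound 4 `Cc1c(C(=O)Nc2ccc(C(F)(F)F)cc2)cnn1-c1cccc(Cl)c1Cl` carries 2,3-dichlorophenyl in place of 3-methylphenyl on an aromatic nitrogen. The nearest guide is compound 1 with its 3-chloro-4-fluorophenyl group, where a 1.9-fold higher number from compound 1 to compound 3 (0.28 log units; within the scatter); the nitro change gave a 4.4-fold higher number from compound 1 to compound 2 (0.64 log units; beyond the scatter). A small move toward a lower number, likely within the scatter, is therefore expected: a 1.7-fold lower number from compound 3 to compound 4 (0.22 log units; within the scatter). Compound 4 is estimated at 1500 nM, between 600 nM and 4000 nM.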

Compound 4, half-maximal inhibitory concentration: 1600 nM
For compound 4 the middle estimate is 1.1-fold (0.03 log units) below the measured one; low and high end bracket the measured number.
By their numbers in this assay, from the lowest: compounds 1, 4 and 3 (each within the scatter of the next); then compound 2.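

Placed on the aromatic nitrogen, the 2,3-dichlorophenyl group cannot be told apart in this assay from either 3-methylphenyl (a 1.6-fold lower number from compound 3 to compound 4 (0.19 log units; within the scatter)) or 3-chloro-4-fluorophenyl (a 1.2-fold higher number from compound 1 to compound 4 (0.09 log units; within the scatter)). Three differently substituted rings therefore fall within the scatter of their neighbours, even with two chlorines on the ring. Only the 4-nitrophenyl compound stands clearly apart (a 3.6-fold lower number from compound 2 to compound 4 (0.55 log units; beyond the scatter)).

On these data alone, whether an aminophenyl or a carboxylic acid on this ring would shift the number remains open. No supporting evidence is available to explain these differences.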